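A few compounds are considered here, and "the series" means these few. Any claim that something is new, unique, unknown or untested is made for them only; others in the source may bear on it.

Measured in a functional assay on NCI-H226 cells (Homo sapiens) for inhibition; a higher number here means a weaker inhibitor of growth, a lower number a stronger inhibitor of growth:
- compound 1 `Nc1ccc(-c2nc3cc(F)ccc3s2)cc1Cl`: 30 nM
- compound 2 `Nc1ccc(-c2nc3cc(F)ccc3s2)cc1I`: 10200 nM

Compound 2 holds the higher of the two numbers, making it the weaker inhibitor of growth. Compound 3 `Nc1ccc(-c2nc3cc(F)ccc3s2)cc1Br` carries bromo in place of iodo on an aromatic carbon, ortho to an amino group: bromo in place of iodo on an aromatic carbon. Among the measured compounds shown here, only one measured step bears on this change, the swap of iodo for chloro, and it is large and beyond the scatter: a 340-fold higher number from compound 1 to compound 2 (2.53 log units; beyond the scatter). A large move to a lower number in this assay is therefore expected, covering much of that distance. For compound 3 the estimate is 200 nM, with an expected range of 20 nM to 4000 nM. The expected step is a 51-fold lower number from compound 2 to compound 3 (1.71 log units; beyond the scatter).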

Compound 3, concentration for 50% growth inhibition: 130 nM
Compound 3: middle estimate off by 1.5-fold (0.19 log units), on the high side, and the stated range covers the measured number.
By their numbers in this assay, from the lowest: compound 1; then compound 3; then compound 2.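

In this assay, the position ortho to an amino group does not simply separate chloro from everything larger: bromo recovers most of the ground lost with iodo (a 78-fold lower number from compound 2 to compound 3 (1.89 log units; beyond the scatter)), yet it still falls short of chloro (a 4.3-fold higher number from compound 1 to compound 3 (0.64 log units; beyond the scatter)). Among these three halogens, the number rises from chloro to bromo to iodo, with the larger part of the rise in the last step. Nothing available accounts for this order. The compounds shown leave open whether fluoro, methyl or a plain hydrogen at this position would extend the series or break it.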